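Swapping the Aryl Group of Compound 2

The source may report more compounds than this note shows. Statements on the series, on what has been measured and on what is new or still open speak of the compounds shown alone.

In a functional assay on MCF7 cells (Homo sapiens) for inhibition, read by MTT assay, with a stated time of 48 h (a higher number here means a weaker inhibitor, a lower number a stronger inhibitor), compound 1 `c1ccc(C(c2c[nH]c3ccccc23)c2c[nH]c3ccccc23)cc1` gives 22200 nM, compound 2 `COc1ccc(C(c2c[nH]c3ccc(Br)cc23)c2c[nH]c3ccc(Br)cc23)c(OC)c1` gives 77500 nM and compound 3 `COc1ccc(OC)c(C(c2c[nH]c3ccc(Br)cc23)c2c[nH]c3ccc(Br)cc23)c1` gives 2800 nM. Compound 2 thus has the highest number of the three. Compound 4 `Brc1ccc(C(c2c[nH]c3ccc(Br)cc23)c2c[nH]c3ccc(Br)cc23)cc1` has 4-bromophenyl in place of 2,4-dimethoxyphenyl on a saturated chain carbon bound to two aromatic carbons. Within the data shown here, one measured step bears on this change, and it is large: a 28-fold lower number from compound 2 to compound 3 (1.44 log units; beyond the scatter), with 2,5-dimethoxyphenyl entering at that carbon. Among the measured compounds shown here, no measured compound carries 4-bromophenyl, so a smaller step in the same direction is expected. The expected step is a 5.2-fold lower number from compound 2 to compound 4 (0.71 log units; beyond the scatter). For compound 4 the estimated value is 15000 nM, with an expected range from 4000 nM to 50000 nM.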

Compound 4, half-maximal inhibitory concentration: 3200 nM
Estimate against measurement, compound 4: 4.7-fold (0.67 log units) above; measured number below the stated range.
By their numbers in this assay, from the lowest: compounds 3 and 4 (each within the scatter of the next); then compound 1; then compound 2.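

In this assay the aryl group on this saturated chain carbon needs no hydrogen-bond acceptor for the lower number to appear: there is a 24-fold lower number from compound 2 to compound 4 (1.38 log units; beyond the scatter) when 4-bromophenyl enters in place of 2,4-dimethoxyphenyl. There is also a 1.1-fold higher number from compound 3 to compound 4 (0.06 log units; within the scatter) so 4-bromophenyl and 2,5-dimethoxyphenyl cannot be told apart here, and of these three groups only 2,4-dimethoxyphenyl stands apart. No available evidence accounts for this difference. From the compounds shown here alone, whether an amine or a carboxylic acid on the phenyl ring, or a longer chain at this carbon, would fit the same picture remains open.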